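Alkynyl uracil series: cytotoxicity outlook for the hexyl analogue

A few compounds are considered here, and "the series" means these few. Any claim that something is new, unique, unknown or untested is made for them only; others in the source may bear on it.

Measured compounds:
compound 1 `O=c1[nH]c(=O)n([C@@H]2O[C@H](CO)[C@@H](O)[C@H]2O)cc1C#CC(O)c1ccccc1` gives 34200 nM
compound 2 `O=c1[nH]cc(C#CC(O)c2ccccc2)c(=O)[nH]1` gives 237000 nM

Both numbers come from an ADME assay on A549 cells (Homo sapiens) for cytotoxicity, read by MTT assay; a lower number here means that less compound is tolerated, a higher number that more compound is tolerated. Going by the values given here, compound 1 holds the lowest of the two numbers; the only other compound is compound 2, which lies a 6.9-fold higher number from compound 1 to compound 2 (0.84 log units; beyond the scatter) away. The structural difference between the two is hydrogen in place of 3,4-dihydroxy-5-(hydroxymethyl)oxolan-2-yl on an aromatic nitrogen.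

Compound 3 `CCCCCCC#Cc1cn([C@@H]2O[C@H](CO)[C@@H](O)[C@H]2O)c(=O)[nH]c1=O` has not yet been measured in this assay. It departs from compound 1 by hexyl in place of hydroxy(phenyl)methyl on a triple-bonded carbon. Among the compounds with values here, the one measured step, from compound 1 to compound 2, alters the aromatic nitrogen substituent, not the group on the triple-bonded carbon, so it does not bear on this change; the series holds no step at that place at all. With nothing to guide the direction, a change beyond the scatter is not expected either way, and the number for compound 3 is estimated close to that of compound 1.

Compound 3 is therefore expected at about 30000 nM, with a range of 9000 nM to 100000 nM. This estimate means a step of a 1.1-fold lower number from compound 1 to compound 3 (0.06 log units; within the scatter), expected to stay within the scatter.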

Compound 3, half-maximal cytotoxic concentration: 87200 nM
For compound 3 the middle estimate is 2.9-fold (0.46 log units) below the measured one, within the range that was stated.
By their numbers in this assay, from the lowest: compound 1; then compound 3; then compound 2.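

In this assay, the group on the triple-bonded carbon now has its first reading: a 2.5-fold higher number from compound 1 to compound 3 (0.41 log units; beyond the scatter), so this place can shift the number beyond the scatter, whereas the earlier step spoke only to the substituent on the aromatic nitrogen. The swap of hydroxy(phenyl)methyl for hexyl removes the six-membered aromatic ring and the hydroxy together, so this one step cannot assign the shift to either feature alone. No measurement on hand gives a reason for the step.

Still open, from the compounds shown here alone, is whether hexyl moves the number the same way on the core of compound 2, where hydrogen takes the place of 3,4-dihydroxy-5-(hydroxymethyl)oxolan-2-yl on the aromatic nitrogen. Also open, going by these compounds, is how the number responds on the triple-bonded carbon to a plain phenyl without the hydroxy, to a longer chain, or to a hexyl chain ending in an amine or a carboxylic acid, any of which would help separate the contributions of ring, hydroxy and chain.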